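A few compounds are considered here, and "the series" means these few. Any claim that something is new, unique, unknown or untested is made for them only; others in the source may bear on it.

The measured compounds and their numbers:
Compound 1, `O=C(/N=C(/NCc1ccccc1)Nc1ccc(Br)cc1)c1ccccc1`, gives 738000 nM in an ADME assay on cells (Peritoneal macrophage, Mus musculus) for cytotoxicity, read by MTT assay, with a stated time of 24 h; on this read-out lower numbers stand for higher toxicity in this test and higher numbers for lower toxicity in this test.
Compound 2, `COc1ccc(N/C(=N\C(=O)c2ccccc2)NCc2ccccc2)cc1`, gives 837000 nM.
Compound 3, `O=C(/N=C(/NCc1ccccc1)Nc1ccc(C(F)(F)F)cc1)c1ccccc1`, gives 18600 nM.

Compound 1 stands second highest of the three: compound 2 is nearest, with a 1.1-fold higher number from compound 1 to compound 2 (0.05 log units; within the scatter), and compound 3 is furthest, with a 40-fold lower number from compound 1 to compound 3 (1.60 log units; beyond the scatter). Compound 4, `O=C(/N=C(/NCc1ccccc1)Nc1ccc(Cl)cc1)c1ccccc1`, differs from compound 1 in one place: chloro in place of bromo on an aromatic carbon. For the measured compounds named here, the steps that bear on this both start from compound 1: methoxy in place of bromo moved nothing beyond the scatter, while trifluoromethyl in place of bromo gave a large drop, echoed by a 45-fold lower number from compound 2 to compound 3 (1.65 log units; beyond the scatter). Going by the values given here, no measured step shows one halogen replacing another, so the step from compound 1 to compound 4 is expected to stay within the scatter, a 1.2-fold lower number from compound 1 to compound 4 (0.09 log units; within the scatter). Compound 4 is therefore estimated at 600000 nM, with a range from 250000 nM to 1300000 nM.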

Compound 4, half-maximal cytotoxic concentration: 827000 nM
Estimate against measurement, compound 4: 1.4-fold (0.14 log units) below, within the range that was stated.
By their numbers in this assay, from the lowest: compound 3; then compounds 1, 4 and 2 (each within the scatter of the next).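

In this assay, chloro in place of bromo brings a second halogen to this position and leaves the number within the scatter (a 1.1-fold higher number from compound 1 to compound 4 (0.05 log units; within the scatter)), and chloro in place of methoxy does likewise (a 1.0-fold lower number from compound 2 to compound 4 (0.01 log units; within the scatter)). Among the four groups, only trifluoromethyl now stands apart, with a large gap to chloro (a 44-fold higher number from compound 3 to compound 4 (1.65 log units; beyond the scatter)). Nothing available here explains that gap. On these data alone, whether an amine or a carboxylic acid at this position would match compound 3 or the other three compounds stays open. So does the place of a nitrile.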